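Methoxy in Place of Chloro on Compound 2

The source may hold more compounds than are shown below. What is called first, only, known or untested is meant among the compounds shown, and "the series" means these compounds.

In a functional assay on A549 cells (Homo sapiens) for antiproliferative activity, read by MTT assay, with a stated time of 48 h (on this read-out lower numbers stand for stronger inhibition and higher numbers for weaker inhibition), compound 1 (`O=C(/C=C/c1ccc(O)c(O)c1)N1CCN(c2ccccc2F)CC1`) gives 1.43 ug/mL and compound 2 (`O=C(/C=C/c1ccc(O)c(O)c1)N1CCN(c2ccccc2Cl)CC1`) gives 1.44 ug/mL while compound 3 (`O=C(/C=C/c1ccc(O)c(O)c1)N1CCN(c2cccc(Cl)c2)CC1`) gives 1.29 ug/mL on the same read-out. Compound 2 therefore stands within the scatter of both other compounds. Compound 4 (`COc1ccccc1N1CCN(C(=O)/C=C/c2ccc(O)c(O)c2)CC1`) follows from compound 2 through one change (methoxy in place of chloro on an aromatic carbon), methoxy in place of chloro on an aromatic carbon. For the measured compounds named here, three measured steps bear on this change. Chloro in place of fluoro gives a 1.0-fold higher number from compound 1 to compound 2 (0.00 log units; within the scatter) and is the closest parallel. Moving to 3-chlorophenyl gives a 1.1-fold lower number from compound 2 to compound 3 (0.05 log units; within the scatter) from 2-chlorophenyl and a 1.1-fold lower number from compound 1 to compound 3 (0.04 log units; within the scatter) from 2-fluorophenyl. On these data alone, all three stay within the scatter, although none of them involves methoxy, so that group remains untested here. No step beyond the scatter is expected in this assay and the estimated change is a 1.0-fold lower number from compound 2 to compound 4 (0.01 log units; within the scatter) on this basis. The expected value for compound 4 is 1.4 ug/mL with an estimated range from 0.9 ug/mL to 2.2 ug/mL in this series.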

Compound 4, half-maximal inhibitory concentration: 0.98 ug/mL
The estimate for compound 4 lay 1.4-fold (0.15 log units) above the measured number; low and high end bracket the measured number.
By their numbers in this assay, from the lowest: compounds 4, 3, 1 and 2 (each within the scatter of the next).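

In this assay, methoxy on this aromatic carbon, ortho to a large group, gives a 1.5-fold lower number from compound 2 to compound 4 (0.17 log units; within the scatter), and in place of fluoro it gives a 1.5-fold lower number from compound 1 to compound 4 (0.16 log units; within the scatter). This position therefore accepts a group of two heavy atoms with one hydrogen-bond acceptor in place of a single halogen atom without a step beyond the scatter, and the step from the other chlorinated compound, 2-methoxyphenyl in place of 3-chlorophenyl, gives a 1.3-fold lower number from compound 3 to compound 4 (0.12 log units; within the scatter). No measurement is available that bears on the cause of these results.

On these data alone, whether an amine, a carboxylic acid or a longer alkoxy chain at this place would step beyond the scatter stays open, as does how 3-methoxyphenyl would compare with 2-methoxyphenyl. As far as these compounds go, all four compounds also share the same core, so the effect of a change there remains open too.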